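The source may hold more compounds than are shown below. What is called first, only, known or untested is meant among the compounds shown, and "the series" means these compounds.

Measured in an assay on DDT1 cells (Cricetulus griseus) for binding affinity to adenosine receptor A1 (Homo sapiens), read by radioligand binding; a lower number here means a stronger inhibitor, a higher number a weaker inhibitor:
compound 1 `CCNC(=O)OC[C@H]1OC(n2cnc3c(NC4CCOC4)ncnc32)[C@H](O)[C@@H]1O`: 167 nM
compound 2 `O=C(NC1CCC1)OC[C@H]1OC(n2cnc3c(NC4CCOC4)ncnc32)[C@H](O)[C@@H]1O`: 306 nM
compound 3 `O[C@@H]1[C@@H](CO/C(S)=N/C2CCCCC2)OC(n2cnc3c(NC4CCOC4)ncnc32)[C@@H]1O`: 253 nM

All three sit close together on the shared core. From compound 1 the steps are a 1.8-fold higher number from compound 1 to compound 2 (0.26 log units; within the scatter) and a 1.5-fold higher number from compound 1 to compound 3 (0.18 log units; within the scatter), both within the scatter, and the pair of compounds 2 and 3 shows a 1.2-fold lower number from compound 2 to compound 3 (0.08 log units; within the scatter), also within the scatter. Compound 4 `O=C(NCc1ccccc1)OC[C@H]1OC(n2cnc3c(NC4CCOC4)ncnc32)[C@H](O)[C@@H]1O` is not yet measured. Its change from compound 1: phenyl in place of methyl on a saturated chain carbon bound to an amide-type nitrogen. The two measured steps from compound 1 both enlarge the group on the carbamate side and both stay within the scatter, so no step beyond the scatter is expected in this assay for compound 4, perhaps a slightly higher number. Compound 4 is therefore estimated at 210 nM, range 80 nM to 550 nM, an expected step of a 1.3-fold higher number from compound 1 to compound 4 (0.10 log units; within the scatter).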

Compound 4, inhibition constant: 1830 nM
The estimate for compound 4 lay 8.7-fold (0.94 log units) below the measured number; measured number outside the range, above it.
By their numbers in this assay, from the lowest: compounds 1, 3 and 2 (each within the scatter of the next); then compound 4.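

In this assay, this position does not accept every larger group: benzyl in place of ethyl gives an 11-fold higher number from compound 1 to compound 4 (1.04 log units; beyond the scatter), whereas cyclobutyl in compound 2 stayed within the scatter. Compound 4 also separates from the other two, with a 6.0-fold higher number from compound 2 to compound 4 (0.78 log units; beyond the scatter) and a 7.2-fold higher number from compound 3 to compound 4 (0.86 log units; beyond the scatter), so the earlier enlargements did not predict this change. Nothing available gives a reason for the step.

Open, going by these compounds, is whether the step follows the phenyl ring or its one-carbon link. Phenyl directly on the nitrogen, a longer phenethyl chain, or a pyridyl ring would bear on this.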